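This account rests on a few compounds, and the source may have more. Where it says the series, first, only, none or still open, it means among the compounds named here.

Measured so far in a functional assay on DU-145 cells (Homo sapiens) for inhibition, read by XTT assay, with a stated time of 72 h; on this read-out lower numbers stand for stronger inhibition and higher numbers for weaker inhibition:
Compound 1 `Cc1ccc(S(=O)(=O)NNC(N)=S)cc1` gives 8980 nM.
Compound 2 `Cc1ccc(S(=O)(=O)NNc2nc(C)cs2)cc1` gives 6960 nM.
Compound 3 `CC(=O)c1sc(NNS(=O)(=O)c2ccc(C)cc2)nc1C` gives 9840 nM.

Compound 3 holds the highest of the three numbers in this assay, yet its gaps to compound 1 and to compound 2 both lie within the scatter, so the three compounds cannot be ranked. The two measured steps, a 1.3-fold lower number from compound 1 to compound 2 (0.11 log units; within the scatter) and a 1.4-fold higher number from compound 2 to compound 3 (0.15 log units; within the scatter), likewise stay within the scatter. Compound 4 `CCOC(=O)c1sc(NNS(=O)(=O)c2ccc(C)cc2)nc1C` differs from compound 3 by ethoxy in place of methyl on a carbonyl carbon; cut one bond further out, the change reads acetyl to ethoxycarbonyl. For the measured compounds named here, no measured step touches this position, so nothing bears directly on the change; the only step involving this part of the molecule, the entry of the acetyl group, stayed within the scatter. He therefore expects a 1.0-fold lower number from compound 3 to compound 4 (0.02 log units; within the scatter) in this assay, a step that stays within the scatter. He estimates compound 4 at 9500 nM, with a range from 3500 nM to 26000 nM.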

Compound 4, half-maximal inhibitory concentration: 4680 nM
Compound 4: the middle estimate sits 2.0-fold (0.31 log units) above what was measured; the measured number falls inside the stated range.
By their numbers in this assay, from the lowest: compounds 4, 2, 1 and 3 (each within the scatter of the next, the first and the last beyond it).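

For the compounds shown here, the change from methyl to ethoxy on a carbonyl carbon gives the first step in this assay to pass the usual scatter: a 2.1-fold lower number from compound 3 to compound 4 (0.32 log units; beyond the scatter), though the step is modest. Against the hydrogen of compound 2, however, ethoxycarbonyl gives only a 1.5-fold lower number from compound 2 to compound 4 (0.17 log units; within the scatter), and the acetyl group also stayed within the scatter, so the group on this carbonyl separates compound 3 from compound 4 while neither group clearly departs from hydrogen. No measurement shown accounts for the difference between the two carbonyl groups.

The compounds shown leave open whether a carboxylic acid, an amide or a longer ester chain at this carbonyl carbon would read like compound 3 or like compound 4. They also leave open whether this modest separation would hold on the core of compound 1 with other groups elsewhere.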